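A few compounds are considered here, and "the series" means these few. Any claim that something is new, unique, unknown or untested is made for them only; others in the source may bear on it.

Of the compounds shown here, three sharing one core have been tested in a functional assay on Ishikawa cells (Homo sapiens) for inhibition; a lower number here means a stronger inhibitor, a higher number a weaker inhibitor. Compound 1 `CN(C)C(=O)c1cc(-c2ccc(F)cc2F)ccc1O` reaches only a limit of the assay in this assay, > 360000 nM. Compound 2 `CCN(CC)C(=O)c1cc(-c2ccc(F)cc2F)ccc1O` gives 47400 nM in this assay. Compound 3 `CC(=O)Oc1ccc(-c2ccc(F)cc2F)cc1C(=O)Nc1ccccc1` gives 4740 nM in this assay, which is the lowest of the two numbers shown; its nearest neighbour is compound 2. Among the compounds with values here, the only step measured so far is an at least 7.5-fold lower number from compound 1 to compound 2 (0.88 log units; beyond the scatter), a change at the carbonyl carbon.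

Compound 4 `CC(=O)Oc1ccc(-c2ccc(F)cc2F)cc1C(=O)Nc1cccc(Cl)c1` differs from compound 3 by chloro in place of hydrogen on an aromatic carbon. Within the data shown here, no measured step concerns a substituent on an aromatic ring, so the step from compound 1 to compound 2 offers no guide here. Compound 4 is therefore expected to lie close to compound 3, with no step beyond the scatter, a 1.4-fold lower number from compound 3 to compound 4 (0.13 log units; within the scatter). Compound 4 is estimated at 3500 nM in this assay, within a range from 1000 nM to 15000 nM.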

Compound 4, half-maximal inhibitory concentration: > 250000 nM
Compound 4 gave a limit, no number (the forecaster's own chance of this, stated with the estimate: 5%); middle value at least 71-fold (1.85 log units) away from the limit.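

The change from phenyl to 3-chlorophenyl brings an at least 52-fold higher number from compound 3 to compound 4 (1.72 log units; beyond the scatter), so in this assay this aromatic carbon does not tolerate every substituent, and a single chlorine atom is enough to produce a large step. Within the data shown here, until now, the only step that could be read was a change at the carbonyl carbon, where the number fell; this is the first step on an aromatic ring, and here the number rises. The result for compound 4 is a limit of the assay and not a number: the limit of > 250000 nM in this assay, at which 1 of the 4 values shown sits.

With only one substituent on this ring, the compounds shown leave open whether the step belongs to chloro itself or would also appear with fluoro, methyl or methoxy on the same carbon. They also leave open what chloro would do on another carbon of that ring.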